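The source may hold more compounds than are shown below. What is called first, only, known or untested is meant among the compounds shown, and "the series" means these compounds.

Values so far in a functional assay on M21 cells (Homo sapiens) for antiproliferative activity, read by sulforhodamine B assay, with a stated time of 48 h; on this read-out higher numbers stand for weaker inhibition and lower numbers for stronger inhibition:
- compound 1 `Cc1ccc(OS(=O)(=O)c2ccc(N3CCN(C)C3=O)cc2)c(C)c1`: 1800 nM
- compound 2 `CN1CCN(c2ccc(S(=O)(=O)Oc3cccc(Br)c3)cc2)C1=O`: 1300 nM
- compound 3 `CN1CCN(c2ccc(S(=O)(=O)Oc3cccc(I)c3)cc2)C1=O`: 400 nM

Compound 2 gives 1300 nM, level with compound 1 within the scatter and above compound 3. Its two measured steps are a 1.4-fold lower number from compound 1 to compound 2 (0.14 log units; within the scatter) and a 3.3-fold lower number from compound 2 to compound 3 (0.51 log units; beyond the scatter).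

Compound 4 `CCCCN1CCN(c2ccc(S(=O)(=O)Oc3cccc(Br)c3)cc2)C1=O` is the next case, and it carries this change from compound 2: propyl in place of hydrogen on a saturated chain carbon bound to an amide-type nitrogen in a ring. The same difference reads methyl to butyl. Among the measured compounds shown here, no measured step touches this place, since all three alter the aryl group on the oxygen, and the largest of them is a 4.5-fold lower number from compound 1 to compound 3 (0.65 log units; beyond the scatter). The series therefore gives no direct guide to this change, only a yardstick of size. In this assay a modest move towards a higher number is expected, of about the size of a 3.3-fold lower number from compound 2 to compound 3 (0.51 log units; beyond the scatter), though this direction is a cautious assumption and the range stays wide on both sides.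

The expected step is a 1.9-fold higher number from compound 2 to compound 4 (0.28 log units; within the scatter).

For compound 4 the estimated value is 2500 nM, with an expected range of 700 nM to 8000 nM.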

Compound 4, half-maximal inhibitory concentration: 35000 nM
Beside the measured number, compound 4's estimate is 14-fold (1.15 log units) below it; measured number above the stated range.
By their numbers in this assay, from the lowest: compound 3; then compounds 2 and 1 (each within the scatter of the next); then compound 4.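

Among the compounds shown here, the place on the saturated chain carbon bound to an amide-type nitrogen in a ring is the first site outside the aryl group on the oxygen to be read in this assay, and it responds strongly, with propyl in place of hydrogen giving a 27-fold higher number from compound 2 to compound 4 (1.43 log units; beyond the scatter) and the aryl group held fixed. This step runs opposite in direction to a 4.5-fold lower number from compound 1 to compound 3 (0.65 log units; beyond the scatter), the largest of the aryl steps, and exceeds it in size, so butyl is poorly tolerated here where methyl is not. No measurement shown bears on the cause of this loss.

Going by these compounds, whether the loss builds gradually with chain length remains open, and an ethyl chain or a chain carrying an amine in place of butyl would test this. Also open, on these data alone, is whether the same change gives a step of like size with 3-iodophenyl on the oxygen.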